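The source may hold more compounds than are shown below. What is called first, only, known or untested is meant among the compounds shown, and "the series" means these compounds.

Among the compounds with values here, compound 1 `NC(=O)C[C@H](NC(=O)c1ccc(C#Cc2ccccc2)cc1)C(=O)NO` stands at the lower of the two values so far in a physicochemical assay for lipophilicity (a higher number here means a more lipophilic compound, a lower number a more polar compound), where compound 1 gives 1. In this assay compound 2 `O=C(N[C@H](CO)C(=O)NO)c1ccc(C#Cc2ccccc2)cc1` gives 2, a gap beyond the usual scatter. Compound 3 `O=C(C[C@H](NC(=O)c1ccc(C#Cc2ccccc2)cc1)C(=O)NO)NCCCO` has not yet been measured. It differs from compound 1 in one place: 3-hydroxypropyl in place of hydrogen on an amide-type nitrogen. Within the data shown here, no measured pair shows this change, so its size is open; a modest rise in this assay is expected, amounting to a number 0.30 log units higher from compound 1 to compound 3 (within the scatter). For compound 3 the expected value in this assay is 1.3, estimated to fall between 0.8 and 1.8.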

Compound 3, distribution coefficient: 2
For compound 3 the middle estimate is 0.70 log units below the measured one, and the stated range ends below it.
By their numbers in this assay, from the lowest: compound 1; then compounds 2 and 3 (each within the scatter of the next).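

On the amide-type nitrogen, whose other neighbour is the carbonyl carbon, the swap of hydrogen for 3-hydroxypropyl gives the first step read at this position: in this assay it amounts to a number 1.00 log units higher from compound 1 to compound 3 (beyond the scatter). The value at this nitrogen therefore moves with what it carries, at least for this one group. Nothing measured here accounts for the size of the step. Still open, from the compounds shown here alone, is whether a plain propyl chain, a longer chain, or an amine at the end of the chain would give a step of similar size at this nitrogen.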